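Swapping a sulfur link for a benzylamine link

The compounds below may be only part of what the source reports. "The series", "measured", "known", "first", "only" and "open" are said of these compounds alone.

Of the compounds shown here, three sharing one fused core have been measured in a functional assay on NCI-H322M cells (Homo sapiens) for inhibition, read by sulforhodamine B assay, with a stated time of 48 h; on this read-out lower numbers stand for stronger inhibition of growth and higher numbers for weaker inhibition of growth. Compound 1, `Nc1cc(N)c2nc(-c3ccccc3)c(Sc3ccc(F)cc3)nc2c1`, carries a (4-fluorophenyl)sulfanyl group; in this assay compound 1 gives 38000 nM. Compound 2, `COc1cc(CNc2nc3cc(N)cc(N)c3nc2-c2ccccc2)cc(OC)c1OC`, carries a benzylamino group with three methoxy substituents, and in this assay compound 2 gives 15800 nM. Compound 3, `CCOC(=O)[C@H](CCC(=O)O)NC(=O)c1ccc(CNc2nc3cc(N)cc(N)c3nc2-c2ccccc2)cc1`, extends a benzylamino group into an amide with an acid side chain; in this assay compound 3 reaches only < 100000 nM, which is a limit of the assay and not a number, as the evidence notes: the limit of < 100000 nM in this assay, at which 1 of the 3 values shown sits. Among the two real numbers, compound 1 holds the higher one, and its gap to compound 2 lies beyond the usual scatter.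

Compound 4, `Nc1cc(N)c2nc(-c3ccccc3)c(NCc3ccc(F)cc3)nc2c1`, is compound 1 with one change: (4-fluorobenzyl)amino in place of (4-fluorophenyl)sulfanyl on an aromatic carbon. Among the measured compounds shown here, no measured pair here shows exactly this exchange, yet compound 2 shows that a benzylamino group on this core can sit at the lower end of the two numbers. Compound 4 is therefore expected to land somewhat lower than compound 1, at roughly 20000 nM, within a range from 8000 nM to 50000 nM. The expected step of a 1.9-fold lower number from compound 1 to compound 4 (0.28 log units; within the scatter) would be modest and only slightly beyond the scatter.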

Compound 4, concentration for total growth inhibition: 11500 nM
The estimate for compound 4 lay 1.7-fold (0.24 log units) above the measured number, within the range that was stated.
By their numbers in this assay, from the lowest: compounds 4 and 2 (each within the scatter of the next); then compound 1.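

In this assay, the exchange at this aromatic carbon next to the ring nitrogen gives a 3.3-fold lower number from compound 1 to compound 4 (0.52 log units; beyond the scatter), so the link between the shared core and the 4-fluorophenyl ring clearly affects the read-out, even though the ring itself stays in place. Among the compounds shown here, this is the first direct comparison at this position, as the earlier compounds differ from one another in more than the link, and it shows that a benzylamino-type group can give a lower number than a sulfanyl-type group when the 4-fluorophenyl ring is held constant. The change replaces sulfur with nitrogen, adds a carbon to the link and brings in a hydrogen-bond donor, but no measurement here bears on which of these features accounts for the step.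

A (4-fluorobenzyl)sulfanyl group and a (4-fluorophenyl)amino group at the same carbon would help separate the identity of the linking atom from the length of the link. An N-methyl-N-(4-fluorobenzyl)amino group would remove the amine hydrogen while keeping the rest of the group, leaving open whether that hydrogen matters to the lower number.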